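A Second Chloro on a Compound at the Limit

This account rests on a few compounds, and the source may have more. Where it says the series, first, only, none or still open, it means among the compounds named here.

In an ADME assay on Vero cells (Chlorocebus sabaeus) for cytotoxicity, with a stated time of 72 h (on this read-out higher numbers stand for weaker inhibition and lower numbers for stronger inhibition), compound 3 (`CCOC(=O)c1cc(/C=C/c2cccc(Cl)c2)on1`) gives > 128000 nM as a limit, not a number. Compound 1 (`CCOC(=O)c1cc(/C=C/c2cccc(C(C)C)c2)on1`) gives > 128000 nM as a limit too. Compound 2 (`CCOC(=O)c1cc(/C=C/c2cccc(C)c2)on1`) also gives > 128000 nM as a limit. Compound 4 (`CCOC(=O)c1cc(/C=C/c2cc(Cl)cc(Cl)c2)on1`) carries one change (chloro in place of hydrogen on an aromatic carbon), chloro in place of hydrogen on an aromatic carbon. The measured swaps offer only a step that the two limits leave unreadable from compound 1 to compound 2 and a step that the two limits leave unreadable from compound 1 to compound 3 and a step that the two limits leave unreadable from compound 2 to compound 3 as guides, so no size carries over. All three compounds share the limit of > 128000 nM in this assay, at which 3 of the 3 values shown sit, and so no step beyond the scatter is expected in this assay for now. The expected outcome is a number no higher from compound 3 to compound 4 (the limit leaves the size open) on present evidence. Compound 4 is expected at 128000 nM with an estimated range of 60000 nM to 200000 nM for a numeric reading.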

Compound 4, half-maximal inhibitory concentration: > 128000 nM
Compound 4 was reported as a limit (the forecaster's own chance of this, stated with the estimate: 75%); the middle value sits exactly at the limit.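

No step can be read from compound 3 to compound 4 in this assay, as both results are limits and not numbers: the limit of > 128000 nM in this assay, at which 4 of the 4 values shown sit.

The compounds shown leave open whether any of these changes on the aromatic ring alters the read-out at all.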